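The source may report more compounds than this note shows. Statements on the series, on what has been measured and on what is new or still open speak of the compounds shown alone.

Of the compounds shown here, two on the shared core have numbers so far in a functional assay on K562 cells (Homo sapiens) for cytotoxicity, read by MTT assay, with a stated time of 72 h; a lower number here means a stronger inhibitor, a higher number a weaker inhibitor. Compound 1 `C=C1C(=O)[C@@]23C(=O)OC[C@]4(C(=O)CCC(C)(C)[C@H]4C=O)[C@@H]2CC[C@@H]1[C@H]3OC(=O)c1ccc(OC)cc1` gives 1650 nM, and compound 2 `C=C1C(=O)[C@@]23C(=O)OC[C@]4(C(=O)CCC(C)(C)[C@H]4C=O)[C@@H]2CC[C@@H]1[C@H]3OC(=O)c1ccccc1F` gives 2860 nM. Going by the values given here, compound 2 therefore stands within the scatter of compound 1, its only neighbour on these numbers, and the two cannot be separated.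

Compound 3 `C=C1C(=O)[C@@]23C(=O)OC[C@]4(C(=O)CCC(C)(C)[C@H]4C=O)[C@@H]2CC[C@@H]1[C@H]3OC(=O)c1ccccc1Cl` is the next case, and its difference from compound 2 is chloro in place of fluoro on an aromatic carbon. This is chloro in place of fluoro on an aromatic carbon of a six-membered aromatic ring of carbon only, ortho to a large group.

Among the compounds with values here, no measured pair covers this exchange directly. Within the data shown here, the only guide is a 1.7-fold higher number from compound 1 to compound 2 (0.24 log units; within the scatter), where 2-fluorophenyl replaced 4-methoxyphenyl on a carbonyl carbon and the shift stayed within the scatter. With a single step to go on, the evidence is thin, and no shift beyond the scatter is expected in this assay, in either direction. The expected step is a 1.1-fold lower number from compound 2 to compound 3 (0.06 log units; within the scatter).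

In this assay the estimate for compound 3 is 2500 nM, with an expected range of 1100 nM to 5500 nM.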

Compound 3, half-maximal inhibitory concentration: 1220 nM
The estimate for compound 3 lay 2.0-fold (0.31 log units) above the measured number; measured number inside the range.
By their numbers in this assay, from the lowest: compounds 3, 1 and 2 (each within the scatter of the next, the first and the last beyond it).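

Going by these compounds alone, at the aromatic carbon ortho to a large group, chloro in place of fluoro gives the first step beyond the scatter in this assay (a 2.3-fold lower number from compound 2 to compound 3 (0.37 log units; beyond the scatter)), so a single-atom exchange at this place can separate two compounds, though only modestly. Within the data shown here, the wider exchange of 4-methoxyphenyl for 2-chlorophenyl stays within the scatter (a 1.4-fold lower number from compound 1 to compound 3 (0.13 log units; within the scatter)), which leaves compound 2 and compound 3 as the only pair differing in one place that the numbers separate. No accompanying measurement bears on this step, and it stands as an observation in this one assay.

Open, as far as these compounds go, is whether the step seen from fluoro to chloro extends to a bromo or iodo group at the same place, or whether a methyl group there would give a similar number, which would show whether a halogen matters at all. Also open, from the compounds shown here alone, is how an unsubstituted phenyl group, a 4-chlorophenyl group, or a ring bearing an amine or a carboxylic acid would read on the shared core.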